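An ethyl group added to compound 2

The source may report more compounds than this note shows. Statements on the series, on what has been measured and on what is new or still open speak of the compounds shown alone.

In a functional assay on KB cells (Homo sapiens) for cytotoxicity (on this read-out lower numbers stand for an effect already at smaller amounts and higher numbers for an effect only at larger amounts of compound), compound 2 `COC1=CC(O)=C(C(=O)/C=C/c2ccccc2)C(=O)C1(C)C` gives 4.1 ug/mL and compound 1 `CCc1ccc(/C=C/C(O)=C2/C(=O)C(C)=C(OC)C(C)(C)C2=O)cc1` gives 6.9 ug/mL. These two values lie within the usual scatter of each other, so neither stands apart on the numbers available. Compound 3 `CCC1=C(OC)C(C)(C)C(=O)C(C(=O)/C=C/c2ccccc2)=C1O` has not yet been measured. It departs from compound 2 by ethyl in place of hydrogen on a double-bonded ring carbon, a carbon that sits next to the ring atom that bears a hydroxy group. Going by the values given here, no measured pair shows what such a change does in this assay, so the expectation rests only on the narrow spread of the two known values. The expected change, a 1.1-fold higher number from compound 2 to compound 3 (0.04 log units; within the scatter), is none beyond the scatter and has no firm direction. For compound 3 the estimated value is 4.5 ug/mL, with an expected range from 2 ug/mL to 10 ug/mL.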

Compound 3, concentration for half-maximal effect: 4.3 ug/mL
Compound 3: the middle estimate sits 1.0-fold (0.02 log units) above what was measured, and the stated range covers the measured number.
By their numbers in this assay, from the lowest: compounds 2, 3 and 1 (each within the scatter of the next).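

Ethyl in place of hydrogen on the double-bonded ring carbon gives a 1.0-fold higher number from compound 2 to compound 3 (0.02 log units; within the scatter) in this assay, the first measured pair to test a change at this position. The position, next to the ring atom that bears a hydroxy group and next to the ring atom that bears a methoxy group, thus accepts an ethyl group here without a shift beyond the scatter. No evidence is available that bears on this result.

As far as these compounds go, whether a longer chain, an amine or a carboxylic acid on this ring carbon would also stay within the scatter remains open. With only ethyl and hydrogen compared here, the compounds shown also leave open how large a group this position can carry before the read-out moves.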